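A few compounds are considered here, and "the series" means these few. Any claim that something is new, unique, unknown or untested is made for them only; others in the source may bear on it.

Compound 1 `CCCCCCCCc1ccc(OCC(=O)Cn2nnc(-c3ccccc3)n2)cc1` is the anchor of this short series. In a physicochemical assay for lipophilicity, read by HPLC, tested at 5 mM (a lower number here means a more polar compound, a higher number a more lipophilic compound), compound 1 gives 8. Compound 2 `CCCCCCCCc1ccc(OC(C)C(=O)Cn2nnc(-c3ccccc3)n2)cc1` differs from it by a methyl in place of hydrogen on a saturated chain carbon bound to a carbonyl carbon and an oxygen on an aromatic ring. In this assay compound 2 returns > 8, which is a limit of the assay and not a number. Compound 2 thus stands at the top of the numbers shown, sitting at the limit of > 8 in this assay, at which 1 of the 2 values shown sits. The step of a number no lower from compound 1 to compound 2 (the limit leaves the size open) is left open in size by that limit.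

Compound 3 `CC(Oc1ccc(Oc2ccc(Cl)cc2)cc1)C(=O)Cn1nnc(-c2ccccc2)n1` departs from compound 2 by 4-chlorophenoxy in place of octyl on an aromatic carbon. Among the measured compounds shown here, no measured step bears directly on this exchange; the one step that exists, a number no lower from compound 1 to compound 2 (the limit leaves the size open), concerns a methyl alone and says nothing about swapping the whole group on the aromatic carbon. The author therefore expects a downward step a number at least 1.00 log units lower from compound 2 to compound 3 (beyond the scatter) in this assay for compound 3, held with wide uncertainty. The estimate for compound 3 in this assay is 7, expected to fall between 6 and 8.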

Compound 3, partition coefficient: 6
The estimate for compound 3 lay 1.00 log units above the measured number; the range from low to high includes it.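

In this assay, among the compounds shown here, the exchange of octyl for 4-chlorophenoxy on an aromatic carbon, para to a large group, is the first change whose step has a readable size, and that size is large: a number at least 2.00 log units lower from compound 2 to compound 3 (beyond the scatter). The two groups carry the same heavy-atom count, so this step comes with no change in that count, only in what the atoms are: an open carbon chain leaves, and a six-membered aromatic ring with an oxygen and a chlorine enters. Compound 2 gives > 8, which is a limit of the assay and not a number, and the size of the step that reaches it from compound 1 cannot be read: the limit of > 8 in this assay, at which 1 of the 3 values shown sits.

Whether the step belongs to the ring, the linking oxygen or the chlorine stays open, as the exchange changes all three at once and neither a plain phenoxy group nor a lone chlorine on that aromatic carbon is among the compounds shown. Also open, on these data alone, is how 4-chlorophenoxy reads on the core of compound 1, without the methyl, and how a shorter chain such as butyl would compare with octyl.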